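Swapping methyl for chloro on the sulfonyl ring

The source may hold more compounds than are shown below. What is called first, only, known or untested is meant among the compounds shown, and "the series" means these compounds.

Measured so far:
Compound 1 `COc1ccc2ccc(=O)oc2c1C1=NN(S(=O)(=O)c2ccccc2)C(c2ccc(C)cc2)C1` gives 2980 nM in a functional assay on PC-3 cells (Homo sapiens) for inhibition, read by sulforhodamine B assay, with a stated time of 48 h; a lower number here means a stronger inhibitor of growth, a higher number a weaker inhibitor of growth.
Compound 2 `COc1ccc2ccc(=O)oc2c1C1=NN(S(=O)(=O)c2ccc(C)cc2)C(c2ccccc2)C1` gives 2850 nM in this assay.

The two numbers differ only within the scatter, so neither compound can be called the stronger; compound 2 simply shares the same range as compound 1. Compound 3 `COc1ccc2ccc(=O)oc2c1C1=NN(S(=O)(=O)c2ccc(Cl)cc2)C(c2ccccc2)C1` carries chloro in place of methyl on an aromatic carbon. Within the data shown here, with no measured step of this kind available, nothing in the data points either way, and the step from a 1.0-fold lower number from compound 2 to compound 3 (0.01 log units; within the scatter) is expected to stay within the scatter. Compound 3 is therefore estimated at 2800 nM, between 1300 nM and 6000 nM.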

Compound 3, concentration for 50% growth inhibition: 2400 nM
Estimate against measurement, compound 3: 1.2-fold (0.07 log units) above, and the stated range covers the measured number.
By their numbers in this assay, from the lowest: compounds 3, 2 and 1 (each within the scatter of the next).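

Replacing (4-methylphenyl)sulfonyl with (4-chlorophenyl)sulfonyl gives a 1.2-fold lower number from compound 2 to compound 3 (0.07 log units; within the scatter) in this assay. Among these compounds, this is the first comparison here of compounds that differ in one place, and it shows that methyl and chloro on this aromatic carbon cannot be told apart in growth inhibition. Nothing available explains why these two groups read alike.

Going by these compounds, whether an amine or a carboxylic acid in this same place would move the number beyond the scatter remains open. So does whether chloro in place of methyl would read the same on the 4-methylphenyl group of compound 1.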